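A few compounds are considered here, and "the series" means these few. Any claim that something is new, unique, unknown or untested is made for them only; others in the source may bear on it.

Measured so far in a functional assay on HeLa cells (Homo sapiens) for cytotoxicity, read by MTT assay; a lower number here means a stronger inhibitor, a higher number a weaker inhibitor:
Compound 1 `CCOC(=O)C12C(=O)OCC=C1COC2c1cccc(Cl)c1`. In this assay compound 1 gives only a limit, > 1000000 nM.
Compound 2 `CCOC(=O)C12C(=O)OCC=C1COC2c1ccc(Cl)cc1`. In this assay compound 2 gives 118000 nM.
Compound 3 `CCOC(=O)C12C(=O)OCC=C1COC2c1ccc(Cl)c(Cl)c1`. In this assay compound 3 gives 72400 nM.

Compound 1 sits at the limit of > 1000000 nM in this assay, at which 1 of the 3 values shown sits. Among the two numbers proper, compound 2 and compound 3 lie within the scatter of each other (a 1.6-fold lower number from compound 2 to compound 3 (0.21 log units; within the scatter)), so neither is ranked above the other. From compound 1 the steps are clearer: an at least 8.4-fold lower number from compound 1 to compound 2 (0.92 log units; beyond the scatter) and an at least 13-fold lower number from compound 1 to compound 3 (1.14 log units; beyond the scatter), both beyond the scatter.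

Compound 4 `CCOC(=O)C12C(=O)OCC=C1COC2c1ccc(OC)cc1` is not yet measured. It differs from compound 2 by methoxy in place of chloro on an aromatic carbon. Among the measured compounds shown here, no measured step swaps chloro for methoxy. The nearest comparison is the chloro-for-hydrogen step, which stayed within the scatter (a 1.6-fold lower number from compound 2 to compound 3 (0.21 log units; within the scatter)); the ring-position step (an at least 8.4-fold lower number from compound 1 to compound 2 (0.92 log units; beyond the scatter)) concerns a different kind of change and carries little weight here. For the measured compounds named here, with no direct precedent, no step beyond the scatter is expected in this assay in either direction, though the spread around that expectation is wide. The step expected is a 1.3-fold higher number from compound 2 to compound 4 (0.10 log units; within the scatter). Compound 4 is estimated at 150000 nM, with a range from 50000 nM to 500000 nM.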

Compound 4, half-maximal inhibitory concentration: 18300 nM
Estimate against measurement, compound 4: 8.2-fold (0.91 log units) above; measured number outside the range, below it.
By their numbers in this assay, from the lowest: compound 4; then compounds 3 and 2 (each within the scatter of the next). At a limit, above all of these: compound 1.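

Notes on this assay: at this aromatic carbon, para to a large group, the choice of group matters even between two compounds that both give numbers, as methoxy in place of chloro yields a 6.4-fold lower number from compound 2 to compound 4 (0.81 log units; beyond the scatter) and places compound 4 clear of compound 2. Among the compounds shown here, this is the first step beyond the scatter with a number at both ends; the only earlier step of that kind, a 1.6-fold lower number from compound 2 to compound 3 (0.21 log units; within the scatter), stayed within the scatter and concerned a chloro added to the ring, not a swap of one group for another. Nothing in the data shown accounts for the size or direction of this step, in which chloro leaves and methoxy enters with its 1 hydrogen-bond acceptor.

From the compounds shown here alone, whether the lower number belongs to methoxy alone stays open, since a hydroxyl, an amine or a longer chain such as ethoxy on this carbon would be needed to tell. Also open, going by these compounds, is whether methoxy gives a step of similar size on the other aromatic carbons of this ring, or alongside a second chloro.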